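Swapping a thienyl ketone for a naphthyl ketone

The compounds below may be only part of what the source reports. "The series", "measured", "known", "first", "only" and "open" are said of these compounds alone.

The measured compounds and their values in a functional assay on A549 cells (Homo sapiens) for cytotoxicity, read by MTT assay, with a stated time of 48 h; on this read-out lower numbers stand for stronger inhibition and higher numbers for weaker inhibition:
compound 1 `COc1cc(-c2nnc3n2NC(c2ccco2)C(C(=O)c2cccs2)S3)cc(OC)c1OC`: 78700 nM
compound 2 `COc1cc(-c2nnc3n2NC(c2cccs2)C(C(=O)c2ccc(C)cc2)S3)cc(OC)c1OC`: 12700 nM
compound 3 `COc1cc(C(=O)C2Sc3nnc(-c4cc(OC)c(OC)c(OC)c4)n3NC2c2cccs2)cc(OC)c1OC`: compound 3 reaches only the limit > 100000 nM, which is not a number.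

Of the two numbers, compound 1 stands highest, with compound 2 giving a lower number. Compound 4 `COc1cc(-c2nnc3n2NC(c2ccco2)C(C(=O)c2cccc4ccccc24)S3)cc(OC)c1OC` differs from compound 1 by naphthalen-1-yl in place of thiophen-2-yl on a carbonyl carbon. Going by the values given here, the only single-change step measured, an at least 7.8-fold higher number from compound 2 to compound 3 (0.89 log units; beyond the scatter), exchanges a different pair of groups on the same carbonyl carbon, so it bears only loosely on this change. A step of modest size in either direction is possible here; the change expected is a 2.0-fold lower number from compound 1 to compound 4 (0.29 log units; within the scatter). Compound 4 is therefore estimated at 40000 nM, within a range from 10000 nM to 150000 nM.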

Compound 4, half-maximal inhibitory concentration: > 100000 nM
Compound 4: a limit, no number; the forecaster's own chance of this, stated with the estimate: 25%; middle value at least 2.5-fold (0.39 log units) from the limit.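

In this assay compound 4 gives > 100000 nM, which is a limit and not a number. Going by these compounds alone, the step is an at least 1.2-fold higher number from compound 1 to compound 4 (0.10 log units; that floor lies within the scatter), so this change on the carbonyl carbon is the first measured with the furan-bearing compound 1, and naphthalen-1-yl gives no lower number than thiophen-2-yl. Its floor alone does not show a real loss.

From the compounds shown here alone, how far compound 4 truly lies from compound 1 stays open: the limit of > 100000 nM in this assay, at which 2 of the 4 values shown sit. Also open is whether a plain methyl or a phenyl carrying an amine on this carbonyl carbon would give a lower number.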